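The compounds below may be only part of what the source reports. "The series", "measured", "known", "first", "only" and "open" are said of these compounds alone.

The study concerns a small set of compounds that share one core and were examined in an assay on cells for displacement of a labelled ligand from transmembrane domain-containing protein TMIGD3 (Homo sapiens), read by scintillation counting, with a stated time of 120 min, tested at 1 uM; a lower number here means less inhibition, a higher number more inhibition at the concentration tested (going by the name of the read-out). Compound 1 `Nc1nccn2cc(-c3ccccc3)nc12` gives 12% in this assay. Compound 2 `Nc1nccn2cc(-c3ccco3)nc12` differs from compound 1 in the aryl ring attached to the shared core; the difference between the two cores is not broken down here. In this assay compound 2 gives 5%. Compound 3 `Nc1nc(Br)cn2cc(-c3ccccc3)nc12` carries the change bromo in place of hydrogen on an aromatic carbon relative to compound 1, and in this assay compound 3 gives 14%. The step of a number 2 percentage points higher from compound 1 to compound 3 (within the scatter) is small, so compounds 1 and 3 cannot be told apart on these numbers, and the values of compounds 1 and 2 likewise lie within the usual scatter of each other.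

Compound 4 `Nc1nc(Br)cn2cc(-c3ccco3)nc12` has not yet been measured. It is related to compound 2 by the change (bromo in place of hydrogen on an aromatic carbon), which is the same change, at the same place, that separates compound 3 from compound 1; among the four compounds this change occurs twice. Among the compounds with values here, because the step of a number 2 percentage points higher from compound 1 to compound 3 (within the scatter) lies within the scatter, the only precedent for this change is a small one. For compound 4 the step of a number 2 percentage points higher from compound 2 to compound 4 (within the scatter) is expected to be similarly small. On that basis compound 4 is expected to give about 7% in this assay, with an estimated range from -5% to 20%.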

Compound 4, a percentage reported as inhibition, at one concentration (the size of the read-out at that concentration, not a potency): 28%
The estimate for compound 4 lay 21 percentage points below the measured number; the whole stated range lies below it.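

In this assay the bromo change gives a number 23 percentage points higher from compound 2 to compound 4 (beyond the scatter), a modest step that is far larger than the one seen on the core of compound 1. The change therefore does not carry over with the same size from one core to the other in this series, and the step measured on one core would not have served as a guide to the step on the other: the same change on two cores in this assay, a number 2 percentage points higher (within the scatter) from compound 1 to compound 3 and a number 23 percentage points higher (beyond the scatter) from compound 2 to compound 4, 21 percentage points apart, beyond the scatter of two such steps. Within the data shown here, this shows only that the two steps differ in this one pair of pairs; it does not show why they differ, it gives no rule for other aryl rings, and, since compound 4 at 28% is a read-out at a single concentration, it says nothing about potency.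

The compounds shown leave open whether chloro, methyl or methoxy on the same aromatic carbon would follow the bromo group on either core. They also leave open whether an aryl ring carrying a nitrile or a carboxylic acid, or an acetyl group on the amino group, would keep, shrink or remove the difference between the two steps.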